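From propylsulfanyl to butylamino on a shared core

A few compounds are considered here, and "the series" means these few. Any claim that something is new, unique, unknown or untested is made for them only; others in the source may bear on it.

Compound 1 `CCOC(=O)c1c(C(C)C)oc2nc(N3CCCC3)ccc12` gives (> 330000 nM), a limit and not a number
Compound 2 `CCCSc1ccc2c(C(=O)OCC)c(C(C)C)oc2n1` gives ("not determined" (no result reported)), no result

In an ADME assay on J774.A1 cells (Mus musculus) for cytotoxicity, read by fluorescence and resazurin assay, with a stated time of 24 h (a lower number here means a stronger inhibitor, a higher number a weaker inhibitor), compound 1 reads > 330000 nM as a limit of the assay, not as an exact number. Compound 2 has no number at all: its entry reads "not determined" (no result reported) and so offers no measured starting point. Compound 3 `CCCCNc1ccc2c(C(=O)OCC)c(C(C)C)oc2n1` is the next to be tested. The change is (butylamino in place of propylsulfanyl on an aromatic carbon) with butylamino in place of propylsulfanyl on an aromatic carbon, next to the ring nitrogen. Among the measured compounds shown here, no measured step exists to show what such a swap does. A modest step toward a lower number is expected in this assay as a cautious guess, which would mean slightly stronger cytotoxicity, and the reading may well stay at the limit. For the measured compounds named here, this expectation rests on compound 1 and its limit of > 330000 nM as the only guide. For compound 3 the estimate is 200000 nM with 60000 nM to 400000 nM as the expected range.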

Compound 3, half-maximal inhibitory concentration: > 328000 nM
Compound 3 gave a limit, no number; the forecaster's own chance of this, stated with the estimate: 55%; middle value at least 1.6-fold (0.21 log units) away from the limit.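

In this assay compound 3 gives > 328000 nM, which is a limit and not a number. Compound 1 also stands at a limit, > 330000 nM. No step can be read between compound 1 and compound 3 from these two limits. The compounds shown leave open whether butylamino in place of pyrrolidin-1-yl changes the result in this assay at all.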